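A few compounds are considered here, and "the series" means these few. Any claim that something is new, unique, unknown or untested is made for them only; others in the source may bear on it.

Measured so far:
compound 1 `CN1CC[C@@H](c2ccc(Cl)cc2)[C@H](C(=O)NCc2ccc(CNC(=O)c3cccc(Cl)c3)cc2)C1` gives 1040 nM
compound 2 `CN1CC[C@@H](c2ccc(Cl)cc2)[C@H](C(=O)NCc2ccc(CNC(=O)c3ccc(Cl)cc3)cc2)C1` gives 1540 nM

Both numbers come from an assay on a subcellular fraction from brain for inhibition of Norepinephrine transporter (Rattus norvegicus); a lower number here means a stronger inhibitor, a higher number a weaker inhibitor. Among the measured compounds shown here, compound 2 stands highest of the two, but its only comparator is compound 1, a 1.5-fold higher number from compound 1 to compound 2 (0.17 log units; within the scatter), so the two cannot be separated on this evidence.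

Compound 3 `CN1CC[C@@H](c2ccc(Cl)cc2)[C@H](C(=O)NCc2ccc(CNC(=O)/C=C/c3ccc(Cl)cc3)cc2)C1` is the next member and differs from compound 2 in one place: 2-(4-chlorophenyl)ethenyl in place of 4-chlorophenyl on a carbonyl carbon. For the measured compounds named here, the single measured step, a 1.5-fold higher number from compound 1 to compound 2 (0.17 log units; within the scatter), exchanged one chlorophenyl for another on the same carbonyl carbon; it says nothing about the entry of the 2-(4-chlorophenyl)ethenyl group, so there is no measured precedent for this change. Going by the values given here, with no step pointing in either direction, the expected step of a 1.0-fold lower number from compound 2 to compound 3 (0.01 log units; within the scatter) is one that remains within the scatter of this assay. Compound 3 is accordingly estimated at 1500 nM, with a range from 600 nM to 4000 nM, the width of that range reflecting the absence of any directly comparable step.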

Compound 3, inhibition constant: > 2000 nM
Compound 3 was reported as a limit; the forecaster's own chance of this, stated with the estimate: 5%; middle value at least 1.3-fold (0.12 log units) away from the limit.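

In this assay compound 3 is recorded only as a limit, > 2000 nM, not as a number. Placing 2-(4-chlorophenyl)ethenyl on the carbonyl carbon in place of 4-chlorophenyl gives an at least 1.2-fold higher number from compound 2 to compound 3 (0.11 log units; that floor lies within the scatter), and placing it there in place of 3-chlorophenyl gives an at least 1.9-fold higher number from compound 1 to compound 3 (0.28 log units; that floor lies within the scatter); both are floors, so the size of each step remains unknown, and neither floor separates compound 3 from its comparator. Among the compounds shown here, the new information at this position is therefore limited to the first entry of a group with a double bond outside the aromatic ring, and the series now has one result that cannot be placed exactly: the limit of > 2000 nM in this assay, at which 1 of the 3 values shown sits.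

On these data alone, it remains open whether the true value of compound 3 lies close to its limit or well beyond it, and so whether the ethenyl unit matters at all. The compounds shown also leave open how a saturated 2-(4-chlorophenyl)ethyl group, or an amine or carboxylic acid on the ring of the chlorophenyl group, would behave at this carbonyl carbon.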